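Arylpiperazine amides of a phenyl-bearing imide: one chloro variation

A few compounds are considered here, and "the series" means these few. Any claim that something is new, unique, unknown or untested is made for them only; others in the source may bear on it.

The series shares a core in which a piperidine or piperazine amide hangs from the imide nitrogen, and the ring amine carries an aryl group. Within the data shown here, compound 1, `Cc1cccc(N2CCN(C(=O)CN3C(=O)CC(C)(c4ccccc4)C3=O)CC2)c1`, is the only member with a numerical result: in a functional assay on the whole organism (strain CD-1) with Mus musculus as the target, in the maximal electroshock model, with a stated time of 0.5 h (a lower number here means that less compound is needed, a higher number that more compound is needed for the effect), compound 1 gives 100 mg/kg. Compound 2, `CC1(c2ccccc2)CC(=O)N(CC(=O)N2CCC(Cc3ccccc3)CC2)C1=O`, is recorded in this assay as "not active" (no number reported). Compound 3, `CC1(c2ccccc2)CC(=O)N(CC(=O)N2CCN(c3ccccc3Cl)CC2)C1=O`, is likewise recorded in this assay as "not active" (no number reported). On the numbers shown, compound 1 therefore stands alone; no comparison of sizes can be drawn between it and the two entries without a figure.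

The next compound to be run is compound 4, `CC1(c2ccccc2)CC(=O)N(CC(=O)N2CCN(c3cccc(Cl)c3Cl)CC2)C1=O`. It differs from compound 1 in one place: 2,3-dichlorophenyl in place of 3-methylphenyl on an amine nitrogen in a ring. Among the measured compounds shown here, no step between two measured compounds is available for this kind of change, so the expectation rests on the weak showing of the whole set. The chlorophenyl analog, compound 3, gave "not active" (no number reported), which leaves the dichlorophenyl variant looking unlikely to improve on compound 1. A step of modest size toward a higher minimum effective dose is expected, a 2.0-fold higher number from compound 1 to compound 4 (0.30 log units; within the scatter), with a real chance that only a limit is reported. Compound 4 is estimated at 200 mg/kg, within 100 mg/kg to 400 mg/kg.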

Compound 4, minimum effective dose: "not active" (no number reported)
Compound 4: no number reported; the estimate stays without a comparison.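

In this assay, among these compounds, compound 4 carries no number, so no step from compound 1 at 100 mg/kg can be read. The compounds shown leave open whether any group other than 3-methylphenyl on the ring amine gives a numerical result in this assay at all. Nothing shown bears on the result for compound 4.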